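The source may report more compounds than this note shows. Statements on the series, on what has been measured and on what is new or still open speak of the compounds shown alone.

Compound 1 `COc1ccc2nccc(C3CN(C4CCN(Cc5cc6ccccc6[nH]5)CC4)C(=O)O3)c2c1` gives 25.1 nM. Compound 2 `O=C1OC(c2ccncc2)CN1C1CCN(Cc2cc3ccccc3[nH]2)CC1` gives < 50200 nM, which is a limit of the assay rather than a number.

Within the data shown here, in an in vitro functional assay on RBL cells for antagonist activity at C-C chemokine receptor type 8 (Homo sapiens), read by FLIPR and calcium flux (on this read-out lower numbers stand for stronger inhibition and higher numbers for weaker inhibition), compound 1 stands as the only real number in the set; the other value is the limit of < 50200 nM in this assay, at which 1 of the 2 values shown sits, so no step between measured compounds can be read. Compound 3 `COc1ccc(CN2CCC(N3CC(c4ccnc5ccc(OC)cc45)OC3=O)CC2)cc1` differs from compound 1 by 4-methoxyphenyl in place of 1H-indol-2-yl on a saturated chain carbon bound to an amine nitrogen in a ring, a change that removes the single hydrogen-bond donor and brings in one hydrogen-bond acceptor. The step from compound 1 to compound 3 is expected to be a 16-fold higher number from compound 1 to compound 3 (1.20 log units; beyond the scatter), toward weaker inhibition and beyond the usual scatter. Compound 3 is therefore estimated at 400 nM, with a range from 60 nM to 4000 nM.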

Compound 3, half-maximal inhibitory concentration: 1260 nM
The estimate for compound 3 lay 3.2-fold (0.50 log units) below the measured number; low and high end bracket the measured number.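

In this assay, among these compounds, 4-methoxyphenyl in place of 1H-indol-2-yl gives a 50-fold higher number from compound 1 to compound 3 (1.70 log units; beyond the scatter), the first step in this set that can be read. This place on a saturated chain carbon bound to an amine nitrogen in a ring therefore matters greatly for inhibition, although compound 3 still gives a real number. Nothing shown accounts for the size of this step.

The change swaps the ring group and removes the hydrogen-bond donor together, so the two cannot be told apart. On these data alone, how a plain phenyl or a 4-hydroxyphenyl would stand at this place remains open.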